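From a Ring-Bound Acid to an Open Amino Acid Chain

The compounds below may be only part of what the source reports. "The series", "measured", "known", "first", "only" and "open" are said of these compounds alone.

Of the compounds shown here, three built on one shared core have been tested in a functional assay on MC-38 cells (Mus musculus) for antiproliferative activity, read by CCK-8 assay, with a stated time of 48 h; a higher number here means a weaker inhibitor, a lower number a stronger inhibitor. Compound 1 `COc1ccc(/C=C\c2cc(OC)c(OC)c(OC)c2)cc1OCc1ccc(CN2CCCC[C@@H]2C(=O)O)cc1` reaches only a limit of the assay, giving > 10000 nM in this assay. Compound 2 `COc1ccc(/C=C\c2cc(OC)c(OC)c(OC)c2)cc1OCc1ccc(CN2CCCCC2C(=O)O)cc1` is drawn without a configuration at the ring carbon where compound 1 carries one; in this assay compound 2 gives 5400 nM, and compound 3 `COc1ccc(/C=C\c2cc(OC)c(OC)c(OC)c2)cc1OCc1ccc(CN2CC[C@@H](O)C2)cc1`, with 3-hydroxypyrrolidin-1-yl in place of 2-carboxypiperidin-1-yl, gives 6900 nM. Compound 2 stands at the low end of the two plain numbers, but the gap to compound 3 is a 1.3-fold higher number from compound 2 to compound 3 (0.11 log units; within the scatter), so neither can be set above the other. The step of an at least 1.8-fold lower number from compound 1 to compound 2 (0.26 log units; that floor lies within the scatter) turns on the fact that one of compounds 1 and 2 is drawn with a defined configuration and the other without, at the place where they differ and starts from a limit, so it is a floor only.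

Compound 4 `COc1ccc(/C=C\c2cc(OC)c(OC)c(OC)c2)cc1OCc1ccc(CN[C@H](C(=O)O)[C@@H](C)O)cc1` is the next step from compound 2: (1-carboxy-2-hydroxypropyl)amino in place of 2-carboxypiperidin-1-yl on a saturated chain carbon bound to an aromatic carbon. Among the measured compounds shown here, the one measured exchange at this position, from compound 2 to compound 3, moved nothing beyond the scatter, and the stereochemical step only sets a floor. Neither bears closely on an open chain with two defined stereocentres, so no shift beyond the scatter is expected. Compound 4 is therefore estimated at 7000 nM, within 3000 nM to 20000 nM. The expected step of a 1.3-fold higher number from compound 2 to compound 4 (0.11 log units; within the scatter) is accordingly small.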

Compound 4, half-maximal inhibitory concentration: > 10000 nM
Compound 4: a limit, no number; the forecaster's own chance of this, stated with the estimate: 35%; middle value at least 1.4-fold (0.15 log units) away from the limit.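

Compound 4 shows that an open chain can stand on this saturated chain carbon bound to an aromatic carbon, with (1-carboxy-2-hydroxypropyl)amino in place of the ring of 2-carboxypiperidin-1-yl, without giving a lower number in this assay: the change reads an at least 1.8-fold higher number from compound 2 to compound 4 (0.26 log units; that floor lies within the scatter), and the exchange for 3-hydroxypyrrolidin-1-yl reads an at least 1.4-fold higher number from compound 3 to compound 4 (0.16 log units; that floor lies within the scatter). Both are floors that lie within the scatter, so the open chain cannot be called weaker than either ring-bearing group, only not better on this evidence. Compound 4 gives a limit of the assay rather than a number, as compound 1 does, so the step between those two cannot be read: the limit of > 10000 nM in this assay, at which 2 of the 4 values shown sit.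

From the compounds shown here alone, how far the true value of compound 4 lies past that limit remains open, and with it the real size of the change from a ring to an open chain. Also open, going by these compounds, is whether a plain piperidin-1-yl without the carboxylic acid, or a longer chain ending in a carboxylic acid, would move the number beyond the scatter at this position.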